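From 4-chlorobenzyl to 3,4-dichlorobenzyl at an assay limit

This account rests on a few compounds, and the source may have more. Where it says the series, first, only, none or still open, it means among the compounds named here.

Compound 1 `NC(=O)c1ccc2[nH]c(-c3ccc(OCCC4CCCCN4Cc4ccccc4)cc3)nc2c1`, compound 2 `COc1ccc(CN2CCCCC2CCOc2ccc(-c3nc4cc(C(N)=O)ccc4[nH]3)cc2)cc1` and compound 3 `NC(=O)c1ccc2[nH]c(-c3ccc(OCCC4CCCCN4Cc4ccc(Cl)cc4)cc3)nc2c1` share one core. In a physicochemical assay for solubility, with a stated time of 3 days, at pH 2 (on this read-out higher numbers stand for higher solubility and lower numbers for lower solubility), compound 1 gives > 400000 nM, which is a limit. Compound 2 gives > 400000 nM, also a limit. From the compounds shown here alone, compound 3 gives > 400000 nM, again only a limit, so its exact place is unknown. The shared picture is the limit of > 400000 nM in this assay, at which 3 of the 3 values shown sit. Compound 4 `NC(=O)c1ccc2[nH]c(-c3ccc(OCCC4CCCCN4Cc4ccc(Cl)c(Cl)c4)cc3)nc2c1` carries one change: chloro in place of hydrogen on an aromatic carbon, with the new chloro ortho to a chloro group. The closest measured change, also chloro in place of hydrogen, is a step that the two limits leave unreadable from compound 1 to compound 3. The other two are a step that the two limits leave unreadable from compound 1 to compound 2 and a step that the two limits leave unreadable from compound 2 to compound 3. Going by the values given here, the estimated change, with no step expected beyond the scatter, is a number no higher from compound 3 to compound 4 (the limit leaves the size open). Compound 4 is estimated at 400000 nM, with an expected range from 150000 nM to 800000 nM.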

Compound 4, solubility: 39000 nM
Compound 4: the middle estimate sits 10-fold (1.01 log units) above what was measured, outside the stated range (below it).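

In this assay, a second chloro group on this aromatic ring, ortho to the first, gives a step that can finally be read: an at least 10-fold lower number from compound 3 to compound 4 (1.01 log units; beyond the scatter). The steps among the three earlier compounds cannot be read, whereas the other two steps to the new compound can: an at least 10-fold lower number from compound 2 to compound 4 (1.01 log units; beyond the scatter) and an at least 10-fold lower number from compound 1 to compound 4 (1.01 log units; beyond the scatter). All three sizes are minimums, because the earlier compounds give only a limit: the limit of > 400000 nM in this assay, at which 3 of the 4 values shown sit.

The compounds shown leave open whether a fluoro or methyl group in the same place would give a similar step. They also leave open how large each step truly is.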